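The source may report more compounds than this note shows. Statements on the series, on what has been measured and on what is new or still open speak of the compounds shown alone.

Measured so far:
compound 1 `COc1cc2c(Oc3ccc(NC(=O)c4cc(-c5ccc(C(F)(F)F)cc5)ccn4)cc3F)ccnc2cc1OCCCN1CCCCC1`, 360 nM
compound 2 `COc1cc2c(Oc3ccc(NC(=O)c4cc(-c5ccc(F)cc5)ccn4)cc3F)ccnc2cc1OCCCN1CCCC1`, 370 nM

Both values come from a functional assay on NCI-H460 cells (Homo sapiens) for cytotoxicity, read by MTT assay, with a stated time of 72 h; a higher number here means a weaker inhibitor, a lower number a stronger inhibitor. Compound 2 stands alongside compound 1 there: the number for compound 2 is 370 nM and that for compound 1 is 360 nM, and the gap between the two lies within the scatter, so neither can be set apart from the other.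

The step under consideration leads from compound 2 to compound 3 `COc1cc2c(Oc3ccc(NC(=O)c4cc(-c5ccc(C(F)(F)F)cc5)ccn4)cc3F)ccnc2cc1OCCCN1CCCC1`. The change is trifluoromethyl in place of fluoro on an aromatic carbon, para to a large group. No step between measured compounds covers this exchange, so the expectation rests on the two numbers shown, which differ little. Compound 3 is expected to give a number close to that of compound 2, with a step of a 1.0-fold lower number from compound 2 to compound 3 (0.01 log units; within the scatter) that is not beyond the scatter in either direction. The estimate for compound 3 in this assay is 360 nM, with a range from 180 nM to 720 nM.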

Compound 3, half-maximal inhibitory concentration: 250 nM
Beside the measured number, compound 3's estimate is 1.4-fold (0.16 log units) above it; low and high end bracket the measured number.
By their numbers in this assay, from the lowest: compounds 3, 1 and 2 (each within the scatter of the next).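

In this assay, the exchange of 4-fluorophenyl for 4-(trifluoromethyl)phenyl now has a direct reading, a 1.5-fold lower number from compound 2 to compound 3 (0.17 log units; within the scatter), so going from one heavy atom to four at this place gives no step beyond the scatter. The chain end now has a reading as well: pyrrolidin-1-yl in place of piperidin-1-yl gives a 1.4-fold lower number from compound 1 to compound 3 (0.16 log units; within the scatter), which again cannot be told apart from no difference. No measurement on hand accounts for either reading.

The compounds shown leave open whether other groups at this place, such as a methoxy, a nitrile or a plain hydrogen, would stay within the scatter of compound 3. Going by these compounds, it also remains open how a morpholine or a dimethylamino group would read at the chain end.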